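Removing the methyl from the oxygen of compound 2

The source may hold more compounds than are shown below. What is called first, only, known or untested is meant among the compounds shown, and "the series" means these compounds.

Compound 2 `COc1cc(C)cc(-c2nn(CC#N)cc2-c2ccnc(-c3ccc(N(C)C)cc3)c2)c1` was tested in a functional assay on MCF7 cells (Homo sapiens) for cytotoxicity, read by sulforhodamine B assay, with a stated time of 48 h, tested at 0.001 uM (a higher number here means a weaker effect of the compound at the concentration tested, a lower number a stronger effect), where compound 2 gives 104%. Going by the values given here, this is the highest of the two numbers recorded here; its only neighbour is compound 1 `Cc1cc(O)cc(-c2nn(CC#N)cc2-c2ccnc(-c3ccc(Oc4ccccc4)cc3)c2)c1`, and in this assay compound 1 gives 92%, a reading lower than that of compound 2 by more than the usual scatter. Compound 1 and compound 2 differ in more than one place, so their two values alone say nothing about any single change.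

Compound 3 `Cc1cc(O)cc(-c2nn(CC#N)cc2-c2ccnc(-c3ccc(N(C)C)cc3)c2)c1` has not yet been measured in this assay. It differs from compound 2 in one place: hydrogen in place of methyl on an oxygen on an aromatic ring. Both measured values sit near the level of no effect at this very low concentration, and compound 1, which carries the same hydroxy group as compound 3, is the lower of the two. On this basis only a small step, if any, is expected, and the change from compound 2 to compound 3 in this assay is estimated at a number 6 percentage points lower from compound 2 to compound 3 (within the scatter), within the scatter. Compound 3 is therefore expected to give about 98%, likely between 85% and 110%.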

Compound 3, a percentage reported as activity, at one concentration (the size of the read-out at that concentration, not a potency): 97%
For compound 3 the middle estimate is 1 percentage points above the measured one; the measured number falls inside the stated range.
By their numbers in this assay, from the lowest: compounds 1, 3 and 2 (each within the scatter of the next, the first and the last beyond it).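

In this assay, replacing methoxy with hydroxy on the aromatic ring gives a number 7 percentage points lower from compound 2 to compound 3 (within the scatter), so at this concentration the methyl on that oxygen makes no difference that can be told from the scatter. Compound 3 also provides a single-change comparison for compound 1, since the hydroxy group stays fixed while dimethylamino takes the place of phenoxy on an aromatic carbon, and this gives a number 5 percentage points higher from compound 1 to compound 3 (within the scatter); the gap between compound 1 and compound 2, which differ in more than one place, thus divides into two single steps that each lie within the scatter. No available evidence bears on the reason for these readings.

From the compounds shown here alone, all of these readings come from one very low concentration and sit near the level of no effect, so it remains open whether the methoxy and hydroxy compounds would separate at higher concentrations, where a real effect could be seen. Also open, going by these compounds, is how a longer chain on that oxygen, such as ethyl, or an amine in place of the hydroxy group would read in this assay.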